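A few compounds are considered here, and "the series" means these few. Any claim that something is new, unique, unknown or untested is made for them only; others in the source may bear on it.

Among the measured compounds shown here, compound 3, `CCc1cc(C)nn1-c1nc(C(F)(F)F)cc(=O)[nH]1`, is one of three compounds measured in a physicochemical assay for solubility, at pH 7.4 (a higher number here means a more soluble compound, a lower number a less soluble compound), in which compound 3 gives 200000 nM. Compound 1, `Cn1ccnc1-c1nc(-c2ccccc2)cc(=O)[nH]1`, gives 200000 nM in this assay, which at the digits shown is level with compound 3 and within the scatter of it, so the two stand together at the top of the three numbers. Compound 2, `Cc1cc(C)n(-c2nc(-c3ccc(NS(C)(=O)=O)cc3)cc(=O)[nH]2)n1`, gives 20000 nM in this assay, a number lower than that of compound 3 and clearly beyond the scatter; compound 2 differs from compound 3 in more than one place, so only the two values themselves can be compared.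

Compound 4, `Cc1cc(NC2CCOCC2)n(-c2nc(C(F)(F)F)cc(=O)[nH]2)n1`, has not yet been measured. Its structure differs from compound 3 in one place: (oxan-4-yl)amino in place of ethyl on an aromatic carbon. For the measured compounds named here, nothing among the measured compounds tracks this single change, so no measured step can be drawn upon. The expectation is that the step of a 1.3-fold lower number from compound 3 to compound 4 (0.12 log units; within the scatter) is small and, if anything, lies within the scatter, since the two compounds that share the trifluoromethyl core, compound 3 with 200000 nM, sit at the top of the range. Compound 4 is therefore estimated to give 150000 nM, within a range from 50000 nM to 300000 nM.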

Compound 4, solubility: 50000 nM
Compound 4: middle estimate off by 3.0-fold (0.48 log units), on the high side; the measured number falls inside the stated range.
By their numbers in this assay, from the lowest: compound 2; then compound 4; then compounds 1 and 3 (each within the scatter of the next).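

Among the compounds shown here, this is the first step in the set that isolates one change: in this assay, (oxan-4-yl)amino in place of ethyl on an aromatic carbon gives a 4.0-fold lower number from compound 3 to compound 4 (0.60 log units; beyond the scatter), so this position of the five-membered aromatic ring with 2 nitrogen does respond to what it carries, and the shared core alone does not hold the number at the top of the range. The change is a bundled one, since ethyl, with 2 heavy atoms, no ring and no hydrogen-bond donors or acceptors, gives way to a group of 7 heavy atoms with one six-membered non-aromatic ring, 1 hydrogen-bond donor and 2 hydrogen-bond acceptors, and the single step cannot divide its size among these features. Nothing available bears on why the number moves as it does.

From the compounds shown here alone, it remains open whether a simple amino group, a methylamino group or an oxan-4-yl group joined directly to the ring carbon would give a similar step. Going by these compounds, it also remains open whether the same replacement would give a step of like size on another core, such as that of compound 2.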